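A few compounds are considered here, and "the series" means these few. Any claim that something is new, unique, unknown or untested is made for them only; others in the source may bear on it.

Two compounds that share one core have been examined in a functional assay on CCRF-CEM cells (Homo sapiens) for cytotoxicity, with a stated time of 72 h; a higher number here means a weaker inhibitor, a lower number a stronger inhibitor. Compound 1 `Nc1nc(=O)n([C@@H]2O[C@H](CO)[C@@H](O)[C@H](O)[C@H]2O)cc1C#Cc1ccccc1` is the parent of the pair. In this assay compound 1 reaches only a limit of the assay, not a number, at > 250000 nM. Compound 2 `CC(C)(C)c1ccc(C#Cc2cn([C@@H]3O[C@H](CO)[C@@H](O)[C@H](O)[C@H]3O)c(=O)nc2N)cc1` carries a tert-butyl in place of hydrogen on an aromatic carbon. In this assay compound 2 likewise gives a limit rather than a number, > 250000 nM. The step that the two limits leave unreadable from compound 1 to compound 2 therefore cannot be read in either direction. Compound 2 thus stands where everything measured so far stands, namely at the limit of > 250000 nM in this assay, at which 2 of the 2 values shown sit. Compound 3 `C#Cc1cn([C@@H]2O[C@H](CO)[C@@H](O)[C@H](O)[C@H]2O)c(=O)nc1N` differs from compound 2 by hydrogen in place of 4-(tert-butyl)phenyl on a triple-bonded carbon. Within the data shown here, the only measured step touches the same part of the molecule and is itself unreadable, so it offers no direction and no size for the change to compound 3. Compound 3 is expected to remain at the limit as well, the expected step of a number no higher from compound 2 to compound 3 (the limit leaves the size open) being none beyond the scatter. For compound 3 the estimate in this assay is 250000 nM, with a range from 50000 nM to 1000000 nM.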

Compound 3, half-maximal inhibitory concentration: > 250000 nM
Compound 3 gave a limit, no number; the forecaster's own chance of this, stated with the estimate: 80%; the middle value lies on the limit itself.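

Compound 3 also gives only a limit in this assay, so neither the step to it from compound 2 nor the step to it from compound 1 can be read, in direction or in size: the limit of > 250000 nM in this assay, at which 3 of the 3 values shown sit.

The compounds shown leave open how compound 1, compound 2 and compound 3 rank against one another, and whether any group on the triple-bonded carbon changes the read-out at all.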